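An imidazole in place of pyrrolidine on the anilide

This account rests on a few compounds, and the source may have more. Where it says the series, first, only, none or still open, it means among the compounds named here.

Compound 1 `COc1ccc(-c2c(Br)c(=O)c3c(OC)cc(OC)cc3n2S(=O)(=O)c2ccc(OC)cc2)cc1`, compound 2 `COc1cc(OC)c2c(=O)cc(C(=O)Nc3ccc(N4CCN(C)CC4)cc3)[nH]c2c1` and compound 3 `COc1cc(OC)c2c(=O)cc(C(=O)Nc3cccc(N4CCCC4)c3)[nH]c2c1` have been examined in an ADME assay on BJ cells (Homo sapiens) for antiproliferative activity, with a stated time of 72 h; a lower number here means that less compound is needed, a higher number that more compound is needed for the effect. In this assay compound 1 gives 49700 nM. For compound 2 the assay reports only a limit, > 19800 nM, and not a number. For compound 3 the assay likewise reports only a limit, > 58600 nM. Where compound 3 stands is thus known only as a limit (the limit of > 58600 nM in this assay, at which 1 of the 3 values shown sits), and compound 2 also sits at a limit (the limit of > 19800 nM in this assay, at which 1 of the 3 values shown sits). Compound 4 `COc1cc(OC)c2c(=O)cc(C(=O)Nc3cccc(-n4ccnc4)c3)[nH]c2c1` has not yet been measured in this assay. Its change from compound 3 is 1H-imidazol-1-yl in place of pyrrolidin-1-yl on an aromatic carbon. For the measured compounds named here, no measured pair of compounds shows the effect of such a change on the shared core of compound 3. Compound 4 is expected to stay near the limit, so the step that the limit leaves unreadable from compound 3 to compound 4 is expected to be none beyond the scatter. The estimate for compound 4 is 60000 nM, ranging from 20000 nM to 150000 nM.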

Compound 4, half-maximal effective concentration: > 16300 nM
Compound 4 was reported as a limit; the forecaster's own chance of this, stated with the estimate: 70%; the middle value lies beyond the limit too.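

In this assay, for the compounds shown here, compound 3 and compound 4 are both reported only as limits, so no step between them can be read. The compounds shown leave open whether 1H-imidazol-1-yl in place of pyrrolidin-1-yl on an aromatic carbon changes the concentration needed at all.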